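Anilino substituent and NF-kappa-B inhibition: methoxy removed

The source may hold more compounds than are shown below. What is called first, only, known or untested is meant among the compounds shown, and "the series" means these compounds.

Compound 1 `COc1ccc(Nc2ccc3c(c2)C(=O)N(C2CCC(=O)NC2=O)C3=O)cc1` gives 29% in an assay on FRT-Jurkat cells for inhibition of nuclear factor NF-kappa-B complex (Homo sapiens), read by flow cytometry, with a stated time of 24 h, tested at 10 uM (on this read-out lower numbers stand for less inhibition and higher numbers for more inhibition at the one concentration tested (going by the name of the read-out)), the highest of the three numbers in hand. Compound 3 `Cc1ccc(Nc2cccc3c2C(=O)N(C2CCC(=O)NC2=O)C3=O)cc1` gives 9% and compound 2 `O=C1CCC(N2C(=O)c3cccc(Nc4ccc(O)cc4)c3C2=O)C(=O)N1` gives 4% in this assay; both stand beyond the scatter below compound 1. Compound 4 `O=C1CCC(N2C(=O)c3ccc(Nc4ccccc4)cc3C2=O)C(=O)N1` has not yet been measured in this assay. It differs from compound 1 in one place: hydrogen in place of methoxy on an aromatic carbon. For the measured compounds named here, the only measured step touching the same aromatic carbon is a number 5 percentage points higher from compound 2 to compound 3 (within the scatter), which is within the scatter; it also runs between two compounds that share the core with compound 1 but not its arrangement, so it bears only loosely on the change here. With that single, small step as guide, no shift beyond the scatter is firmly expected, though the loss of the substituent leaves room for a modest drop. Compound 4 is expected to reach about 20% in this assay, with a range from 5% to 38%, an estimated step of a number 9 percentage points lower from compound 1 to compound 4 (within the scatter).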

Compound 4, a percentage reported as inhibition, at one concentration (the size of the read-out at that concentration, not a potency): 6%
For compound 4 the middle estimate is 14 percentage points above the measured one; low and high end bracket the measured number.
By their numbers in this assay, from the lowest: compounds 2, 4 and 3 (each within the scatter of the next); then compound 1.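

Notes on the anilino ring: replacing 4-methoxyphenyl with phenyl, on an aromatic carbon para to a large group, gives a number 23 percentage points lower from compound 1 to compound 4 (beyond the scatter) in this assay. For the compounds shown here, the only earlier step at this carbon, a number 5 percentage points higher from compound 2 to compound 3 (within the scatter), joined two compounds of another arrangement, so this is the first step beyond the scatter at this carbon and the first in the arrangement of compound 1, and it shows that the number depends on the methoxy being present. Nothing measured here explains the step.

Still open, from the compounds shown here alone, is whether the methoxy is specific, or whether another group at this carbon, such as an ethoxy, an amine or a fluorine, would serve equally. Also open, going by these compounds, is how hydroxy and methyl behave at this carbon in the arrangement of compound 1.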